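A Bromophenyl Swap in a Flat Cytotoxicity Series

The source may hold more compounds than are shown below. What is called first, only, known or untested is meant among the compounds shown, and "the series" means these compounds.

Of the compounds shown here, three built on one shared core have so far been tested in a functional assay on MCF7 cells (Homo sapiens) for cytotoxicity, read by cell counting, with a stated time of 48 h; a higher number here means a weaker inhibitor, a lower number a stronger inhibitor. Compound 1 `Cc1ccc(-n2cc(COc3cccc4cnc(Nc5cccc(Cl)c5)nc34)nn2)c([N+](=O)[O-])c1` gives 4000 nM. Compound 2 `COc1ccccc1-n1cc(COc2cccc3cnc(Nc4cccc(Cl)c4)nc23)nn1` gives 6000 nM, and compound 3 `Clc1cccc(Nc2ncc3cccc(OCc4cn(Cc5c(Cl)cccc5Cl)nn4)c3n2)c1` gives 6000 nM. Going by the values given here, compound 3 therefore stands level with compound 2, and it also lies within the usual scatter of compound 1, so no compound separates from the others.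

The next compound is compound 4 `Clc1cccc(Nc2ncc3cccc(OCc4cn(-c5ccc(Br)cc5)nn4)c3n2)c1`, in which 4-bromophenyl takes the place of 2,6-dichlorobenzyl on an aromatic nitrogen. The counted difference is 4-bromophenyl in place of 2,6-dichlorobenzyl on an aromatic nitrogen.

The three measured steps all change the group on this same nitrogen. They are a 1.5-fold higher number from compound 1 to compound 2 (0.18 log units; within the scatter), a 1.5-fold higher number from compound 1 to compound 3 (0.18 log units; within the scatter) and no change at the digits printed from compound 2 to compound 3 (within the scatter). Each is within the scatter, including the two that exchange a substituted phenyl for 2,6-dichlorobenzyl, the reverse kind of swap to the one made here. Among the compounds with values here, no measured compound carries bromine, so that part of the change remains untested. Three compounds are also a thin basis for any forecast.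

On this evidence, no change beyond the scatter is expected. The expected step is a 1.2-fold lower number from compound 3 to compound 4 (0.08 log units; within the scatter). Compound 4 is estimated at 5000 nM, with an expected range from 2500 nM to 10000 nM.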

Compound 4, half-maximal inhibitory concentration: 9000 nM
Compound 4: middle estimate off by 1.8-fold (0.26 log units), on the low side; low and high end bracket the measured number.
By their numbers in this assay, from the lowest: compounds 1, 2, 3 and 4 (each within the scatter of the next, the first and the last beyond it).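

In this assay, going by these compounds alone, this nitrogen now carries bromine for the first time, and the exchange for 2,6-dichlorobenzyl gives a 1.5-fold higher number from compound 3 to compound 4 (0.18 log units; within the scatter), while the exchange for 2-methoxyphenyl gives a 1.5-fold higher number from compound 2 to compound 4 (0.18 log units; within the scatter), so neither step separates the compounds involved. The comparison with 4-methyl-2-nitrophenyl gives a 2.3-fold higher number from compound 1 to compound 4 (0.35 log units; beyond the scatter), a modest step and the only one so far at this position to pass beyond the scatter, which shows that the group on this nitrogen can shift the number measurably, though only between these two compounds of the four, since compound 2 and compound 3 remain within the scatter of both. Nothing measured here bears on the reason for this difference between the two groups.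

The compounds shown do not separate the bromine from the phenyl ring that carries it, a question that plain phenyl or 4-chlorophenyl on the same nitrogen would address. They also leave open how this position would respond to a group with no aromatic ring at all, such as a simple butyl chain, an amine or a carboxylic acid.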